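Chloro for Hydrogen on a Fused Core: Growth Inhibition

The compounds below may be only part of what the source reports. "The series", "measured", "known", "first", "only" and "open" are said of these compounds alone.

Measured compounds:
compound 1 `ClCc1ccccc1Cn1cnc2c(Cl)nc(Cl)nc21`: 360 nM
compound 2 `ClCc1ccccc1Cn1cnc2c(Cl)ncnc21`: 1820 nM
compound 3 `ClCc1ccccc1Cn1cnc2ncnc(Cl)c21`: 2340 nM

The three compounds were tested in a functional assay on CAKI-1 cells (Homo sapiens) for cytotoxicity, read by sulforhodamine B assay, with a stated time of 48 h; on this read-out higher numbers stand for weaker inhibition of growth and lower numbers for stronger inhibition of growth. Compound 2 and compound 1 differ in one place, (chloro in place of hydrogen on an aromatic carbon), and the step is a 5.1-fold lower number from compound 2 to compound 1 (0.70 log units; beyond the scatter). Compound 3 is built from the same atoms as compound 2, joined differently; the difference between the two cores is not broken down here. In this assay compound 3 and compound 2 lie within the usual scatter of each other, while compound 1 sits beyond the scatter from both.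

Compound 4 `ClCc1ccccc1Cn1cnc2nc(Cl)nc(Cl)c21` is not yet measured. It stands to compound 3 as compound 1 stands to compound 2: the change is chloro in place of hydrogen on an aromatic carbon, the same change at a place described in the same way. Among the compounds with values here, since the one measured instance of this change gave a 5.1-fold lower number from compound 2 to compound 1 (0.70 log units; beyond the scatter), a step of similar size is expected for compound 4, namely a 4.7-fold lower number from compound 3 to compound 4 (0.67 log units; beyond the scatter), resting on that single example alone. In this assay compound 4 is therefore expected to give about 500 nM, most likely between 200 nM and 1300 nM.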

Compound 4, concentration for 50% growth inhibition: 19500 nM
For compound 4 the middle estimate is 39-fold (1.59 log units) below the measured one, outside the stated range (above it).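

In this assay, the chloro change did not carry over from one core to the other: it now gave an 8.3-fold higher number from compound 3 to compound 4 (0.92 log units; beyond the scatter), opposite in direction to a 5.1-fold lower number from compound 2 to compound 1 (0.70 log units; beyond the scatter). Set side by side, the two steps differ by more than repeated measurement would explain: the same change on two cores in this assay, a 5.1-fold lower number (0.70 log units; beyond the scatter) from compound 2 to compound 1 and an 8.3-fold higher number (0.92 log units; beyond the scatter) from compound 3 to compound 4, 42-fold (1.62 log units) apart, beyond the scatter of two such steps This shows that in this series the result of adding this chloro depends on the core that carries it, so a step read on one core cannot be used as an estimate for the other, but with a single pair on each core it does not show why the two cores part ways, nor how the change would behave on any further core.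

The compounds shown leave open whether a different group on the aromatic carbon between two ring nitrogen atoms, such as an amine or a methoxy group, would also pull the two cores apart. They also leave open whether the opposite steps would hold on cells other than those tested here.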